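Compound 3 to compound 4: replacing chloro

This account rests on a few compounds, and the source may have more. Where it says the series, first, only, none or still open, it means among the compounds named here.

Compound 1 `O=C(O)c1cnc(-c2ccc(C(F)(F)F)cc2)[nH]c1=O`: > 5 mg/kg, a limit.
Compound 2 `C=CCc1cccc(-c2ncc(C(=O)O)c(=O)[nH]2)c1O`: > 0.5 mg/kg, a limit.
Compound 3 `CCOc1ccc(Cl)cc1-c1ncc(C(=O)O)c(=O)[nH]1`: 0.5 mg/kg.

The series is read in a functional assay on the whole organism (strain Sprague-Dawley) for inhibition, with Rattus norvegicus as the target, with a stated time of 10 min; a lower number here means that less compound is needed, a higher number that more compound is needed for the effect. Within this small set, compound 3 holds the only actual number, since the results for compound 1 and compound 2 are limits. That makes compound 3 the single numerical reference point for the next step.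

Compound 4 `CCOC(=O)C(=O)Nc1ccc(OCC)c(-c2ncc(C(=O)O)c(=O)[nH]2)c1` carries ((ethoxycarbonyl)carbonyl)amino in place of chloro on an aromatic carbon, para to an ethoxy group and meta to a large group (((ethoxycarbonyl)carbonyl)amino in place of chloro on an aromatic carbon). The rest of the structure matches compound 3.

Among the compounds with values here, the measured compounds offer no step that differs in one place, so this replacement has no direct precedent. No step beyond the usual scatter is expected as the central case, with a slight lean towards a lower number in this assay. The expected change is a 1.7-fold lower number from compound 3 to compound 4 (0.22 log units; within the scatter). Within the data shown here, the only numerical anchor is compound 3 at 0.5 mg/kg, so the range is kept wide on both sides. For compound 4 the estimated value is 0.3 mg/kg, with an expected range from 0.05 mg/kg to 2 mg/kg.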

Compound 4, dose for 50% inhibition: 25 mg/kg
Estimate against measurement, compound 4: 83-fold (1.92 log units) below; measured number above the stated range.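

In this assay, within the data shown here, replacing chloro with ((ethoxycarbonyl)carbonyl)amino gives a 50-fold higher number from compound 3 to compound 4 (1.70 log units; beyond the scatter), the only step that can be read so far. This shows that the aromatic carbon para to the ethoxy group is not indifferent to its substituent: with the shared core otherwise unchanged, exchanging 1 heavy atom for 8 heavy atoms, including 1 hydrogen-bond donor and 3 hydrogen-bond acceptors, moves the number well beyond the scatter. The values shown offer no measured property that would account for this step.

The compounds shown leave open whether the whole ((ethoxycarbonyl)carbonyl)amino group accounts for the step or only part of it, a question that a plain amine, an acetylamino group or the carboxylic acid in place of the ethyl ester at the same carbon would help to separate. They also leave open how narrowly this carbon tolerates change, as a fluoro, bromo or methyl group there would show by comparison with compound 3 at 0.5 mg/kg.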